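Swapping the trihydroxyphenyl ring for a bromophenyl ring

The source may report more compounds than this note shows. Statements on the series, on what has been measured and on what is new or still open speak of the compounds shown alone.

Compound 1 `Cc1ccc(CS/C(=C/c2c(O)cc(O)cc2O)C(=O)c2ccc(Cl)cc2)cc1` in a functional assay on DU-145 cells (Homo sapiens) for inhibition, read by trypan blue exclusion, with a stated time of 96 h (a higher number here means a weaker inhibitor of growth, a lower number a stronger inhibitor of growth), gives 50000 nM. Compound 2 `Cc1ccc(S/C(=C/c2c(O)cc(O)cc2O)C(=O)c2ccc(Cl)cc2)cc1` in this assay gives only a limit, > 100000 nM.

Compound 1 thus carries the only number shown; the other value sits at the limit of > 100000 nM in this assay, at which 1 of the 2 values shown sits. For the measured compounds named here, the single measured step, an at least 2.0-fold higher number from compound 1 to compound 2 (0.30 log units; that floor lies within the scatter), concerns the group on the sulfur and says nothing about the ring that changes here. Compound 3 `Cc1ccc(CS/C(=C/c2ccc(Br)cc2)C(=O)c2ccc(Cl)cc2)cc1` differs from compound 1 by 4-bromophenyl in place of 2,4,6-trihydroxyphenyl on a double-bonded chain carbon bound to a double-bonded chain carbon. Going by the values given here, no measured step bears on this change, so no step beyond the scatter is expected, a 1.2-fold higher number from compound 1 to compound 3 (0.08 log units; within the scatter). Compound 3 is estimated at 60000 nM, from 20000 nM to 200000 nM.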

Compound 3, concentration for 50% growth inhibition: 10000 nM
For compound 3 the middle estimate is 6.0-fold (0.78 log units) above the measured one; the measured number lies below the stated range.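

In this assay, the 2,4,6-trihydroxyphenyl ring on this double-bonded chain carbon can be replaced without losing growth inhibition, and the number even improves: a 5.0-fold lower number from compound 1 to compound 3 (0.70 log units; beyond the scatter). The entering 4-bromophenyl ring has 0 hydrogen-bond donors, so the donors of the leaving ring are not required for this activity. Nothing measured here explains the step. Whether the bromine or the loss of the hydroxyl groups accounts for it stays open. So does how an unsubstituted phenyl ring or a 4-methoxyphenyl ring would behave here.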